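The compounds below may be only part of what the source reports. "The series", "measured", "known", "first", "only" and "open" are said of these compounds alone.

Compound 3 (`O=C(Nc1cccc(F)c1)c1cc(=O)[nH]c2cc(-c3ccccc3F)ccc12`) stands at a limit in a functional assay on KYSE-410 cells (Homo sapiens) for antiproliferative activity, read by MTT assay, with a stated time of 72 h (a lower number here means a stronger inhibitor, a higher number a weaker inhibitor), > 20000 nM, and not at a number. Compound 1 (`CC(C)(C)c1ccc(-c2ccc3c(C(=O)Nc4cccc(F)c4)cc(=O)[nH]c3c2)cc1`) also gives only a limit, > 20000 nM. Compound 2 (`O=C(Nc1cccc(F)c1)c1cc(=O)[nH]c2cc(-c3ccsc3)ccc12`) gives 4300 nM. Compound 4 (`O=C(Nc1cccc(F)c1)c1cc(=O)[nH]c2cc(-c3cccnc3F)ccc12`) carries 2-fluoropyridin-3-yl in place of 2-fluorophenyl on an aromatic carbon. The swaps at this same place bear on it: an at least 4.6-fold lower number from compound 1 to compound 2 (0.66 log units; beyond the scatter), an at least 4.6-fold higher number from compound 2 to compound 3 (0.66 log units; beyond the scatter) and a step that the two limits leave unreadable from compound 1 to compound 3. The nearest comparison is the 2-fluorophenyl group of compound 3 at > 20000 nM, a limit, so a result close to that limit is expected. The expected change is small and towards a lower number: an at least 1.4-fold lower number from compound 3 to compound 4 (0.15 log units; that floor lies within the scatter). For compound 4 the estimated value in this assay is 14000 nM, with an expected range of 5000 nM to 30000 nM.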

Compound 4, half-maximal inhibitory concentration: 11600 nM
For compound 4 the middle estimate is 1.2-fold (0.08 log units) above the measured one, and the stated range covers the measured number.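

In this assay this position now holds a six-membered aromatic ring that returns a number rather than a limit, yet the steps read an at least 1.7-fold lower number from compound 3 to compound 4 (0.23 log units; that floor lies within the scatter) and an at least 1.7-fold lower number from compound 1 to compound 4 (0.23 log units; that floor lies within the scatter), so neither establishes a gain. Thiophen-3-yl stays the better group on the one step between two numbers: a 2.7-fold higher number from compound 2 to compound 4 (0.43 log units; beyond the scatter). Both other six-membered groups stay at a limit: the limit of > 20000 nM in this assay, at which 2 of the 4 values shown sit.

On these data alone, the true size of the change from 2-fluorophenyl to 2-fluoropyridin-3-yl stays open, with only a floor available. Also open, as far as these compounds go, is how furan-3-yl, pyridin-3-yl without fluorine or a morpholine would read at this place.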